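The source may report more compounds than this note shows. Statements on the series, on what has been measured and on what is new or still open speak of the compounds shown alone.

Measured so far in an ADME assay for pharmacokinetics, at pH 7.4; on this read-out lower numbers stand for a shorter-lived compound and higher numbers for a longer-lived compound:
compound 1 `COc1cnc(C[S+]([O-])c2nc3cc(OC(F)F)ccc3[nH]2)c(C)c1OC` gives 60 h
compound 2 `COc1ccnc(C[S+]([O-])c2nc3cc(OC(F)F)ccc3[nH]2)c1C` gives 3 h
compound 3 `COc1cnc(C[S+]([O-])c2nc3cc(OC(F)(F)C(F)F)ccc3[nH]2)cc1OC` gives 140 h

Compound 3 shows the highest number of the three. From compound 1 to compound 2 the change is hydrogen in place of methoxy on an aromatic carbon, and it made a 20-fold lower number from compound 1 to compound 2 (1.30 log units; beyond the scatter).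

Compound 4 `COc1ccnc(C[S+]([O-])c2nc3cc(OC(F)(F)C(F)F)ccc3[nH]2)c1` has not yet been measured. It differs from compound 3 by hydrogen in place of methoxy on an aromatic carbon. Within the data shown here, this is the same kind of change as the one from compound 1 to compound 2, but not quite the same: in compound 1 the place is also meta to a methyl group, and compound 3 has no such group there. Among the measured compounds shown here, how the core of compound 3 differs from the core of compound 1 is not broken down here; the two values show only that compound 3 sits higher than compound 1.

In this assay the step of a 20-fold lower number from compound 3 to compound 4 (1.30 log units; beyond the scatter) is expected for compound 4, a step of about the size seen earlier, because a 20-fold lower number from compound 1 to compound 2 (1.30 log units; beyond the scatter) came from the same kind of change. The estimate for compound 4 is 7 h, expected to fall between 3 h and 20 h.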

Compound 4, half-life: 63 h
For compound 4 the middle estimate is 9.0-fold (0.95 log units) below the measured one; measured number above the stated range.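

Replacing methoxy with hydrogen gave a lower number on both cores in this assay, but the size of the step did not carry from one core to the other: the same change on two cores in this assay, a 20-fold lower number (1.30 log units; beyond the scatter) from compound 1 to compound 2 and a 2.2-fold lower number (0.35 log units; beyond the scatter) from compound 3 to compound 4, 9.0-fold (0.95 log units) apart, beyond the scatter of two such steps. On the second core the change gave a 2.2-fold lower number from compound 3 to compound 4 (0.35 log units; beyond the scatter), so the direction held, while the earlier step proved a poor guide to the size. These two pairs do not show why the steps differ: the two cores differ in more than one place, including the methyl group that compound 1 carries and compound 3 lacks, and nothing here separates the contribution of each difference.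

From the compounds shown here alone, it remains open whether the methyl group alone decides the size of the step, which a version of compound 3 carrying that methyl group could test. Also open, going by these compounds, is how an amine or an ethoxy group in place of the methoxy would behave on either core.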